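Methyl to methoxy on the aryl ring of compound 1

The compounds below may be only part of what the source reports. "The series", "measured", "known", "first", "only" and "open" are said of these compounds alone.

compound 1 `Cc1ccc(Nc2cc(NC(=O)Nc3c(Cl)cccc3Cl)ncn2)cc1C` — 41.3%
compound 2 `COc1cc(NC(=O)Nc2cc(Nc3cccc(C(C)(C)C)c3)ncn2)cc(OC)c1` — 40%
compound 3 `COc1cc(NC(=O)Nc2cc(Nc3ccc(F)c(Cl)c3)ncn2)cc(OC)c1` — 36.7%

In a functional assay on NCI-H226 cells (Homo sapiens) for inhibition, read by MTT assay, with a stated time of 48 h, tested at 10 uM (on this read-out lower numbers stand for less inhibition and higher numbers for more inhibition at the one concentration tested (going by the name of the read-out)), compound 1 gives 41.3%, the top number of the three, yet its gaps to compound 2 and to compound 3 both lie within the scatter. Going by the values given here, the one measured step, a number 3.3 percentage points lower from compound 2 to compound 3 (within the scatter), swaps the group on a nitrogen on an aromatic ring and is itself within the scatter. Compound 4 `COc1ccc(Nc2cc(NC(=O)Nc3c(Cl)cccc3Cl)ncn2)cc1C` differs from compound 1 by methoxy in place of methyl on an aromatic carbon. Among the compounds with values here, no measured step touches this position, so nothing in the set points to a change beyond the scatter. The expected step of a number 1.3 percentage points lower from compound 1 to compound 4 (within the scatter) is therefore close to nothing. Compound 4 is estimated at 40% in this assay, with a range from 28% to 52%.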

Compound 4, a percentage reported as inhibition, at one concentration (the size of the read-out at that concentration, not a potency): 50%
The estimate for compound 4 lay 10 percentage points below the measured number; measured number inside the range.
By their numbers in this assay, from the lowest: compounds 3, 2, 1 and 4 (each within the scatter of the next, the first and the last beyond it).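

In this assay, methoxy in place of methyl, on the aromatic carbon para to a large group, gives a number 8.7 percentage points higher from compound 1 to compound 4 (within the scatter). Going by these compounds alone, this is the only measured change at this position, so the 4-methoxy-3-methylphenyl group and the 3,4-dimethylphenyl group cannot be told apart here. No supporting data bear on this step.

As far as these compounds go, whether a hydroxyl, an ethoxy or an amine on this carbon would give a step beyond the scatter stays open. Also open, from the compounds shown here alone, is what the methyl group ortho to this carbon contributes.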